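The compounds below may be only part of what the source reports. "The series", "measured", "known", "first", "only" and "open" are said of these compounds alone.

Three compounds have been measured in an ADME assay on cells (Mus musculus, strain BALB/C) for cytotoxicity, read by MTT assay, with a stated time of 24 h; on this read-out lower numbers stand for higher toxicity in this test and higher numbers for lower toxicity in this test:

compound 1 `Cc1ccc(C(=O)N/N=C/c2ccccc2O)c(O)c1` — 761000 nM
compound 2 `COc1cccc(/C=N/NC(=O)c2ccc(C)cc2O)c1` — 672000 nM
compound 3 `Cc1ccc(C(=O)N/N=C/c2cc(Cl)cc(Cl)c2O)c(O)c1` — 708000 nM

The three numbers sit close together. Compound 1 stands at one end of this narrow span, but its gap to compound 3, the nearest of the other two, and its gap to compound 2, the furthest, both lie within the usual scatter of this assay, so the three compounds cannot be told apart on these numbers.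

Compound 4 `Cc1ccc(C(=O)N/N=C/c2ccccc2[N+](=O)[O-])c(O)c1` shares the core of compound 1 and differs from it in a single place: nitro in place of hydroxy on an aromatic carbon. For the measured compounds named here, no step between two measured compounds isolates this change, and the three measured values give no ground for expecting a shift beyond the scatter in this assay in either direction. For compound 4 the expected step is therefore a 1.1-fold lower number from compound 1 to compound 4 (0.04 log units; within the scatter). Compound 4 is accordingly estimated to give about 700000 nM, with a range from 350000 nM to 1400000 nM.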

Compound 4, half-maximal cytotoxic concentration: 644000 nM
Compound 4: the middle estimate sits 1.1-fold (0.04 log units) above what was measured, within the range that was stated.
By their numbers in this assay, from the lowest: compounds 4, 2, 3 and 1 (each within the scatter of the next).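

The change at this position can now be read directly in this assay: nitro in place of hydroxy on an aromatic carbon, ortho to a large group, gives a 1.2-fold lower number from compound 1 to compound 4 (0.07 log units; within the scatter). At this one place, then, the loss of a hydrogen-bond donor and the gain of two heavy atoms and a double bond outside aromatic rings come with no shift that can be told from the scatter. No measurement shown here offers an explanation for this result.

The compounds shown leave open whether an amine or a carboxylic acid on this same aromatic carbon would also stay within the scatter of compound 1. From the compounds shown here alone, it also remains open whether nitro in place of hydroxy would read the same way on the core of compound 3.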